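The source may hold more compounds than are shown below. What is called first, only, known or untested is meant among the compounds shown, and "the series" means these compounds.

In a physicochemical assay for lipophilicity, read by HPLC, at pH 7.5 (a lower number here means a more polar compound, a higher number a more lipophilic compound), three compounds sharing one core have been measured: compound 1 `CCCN(CCC)C(=O)Cc1c(-c2ccc(OC)cc2)nn2c(CC)cc(CC)nc12` gives 3.35, compound 2 `CCc1cc(CC)n2nc(-c3ccc(OC)cc3)c(CC(=O)N(CC)C(C)(C)C)c2n1` gives 3.32, and compound 3 `CCc1cc(CC)n2nc(-c3ccc(OC)cc3)c(CC(=O)N(C)c3ccccc3)c2n1` gives 3.11. Compound 3 therefore stands level with the other two, all three numbers lying within the usual scatter. Compound 4 `CCc1cc(CC)n2nc(-c3ccc(OC)cc3)c(CC(=O)N3CCCC3)c2n1` differs from compound 3 in one place: pyrrolidin-1-yl in place of methyl(phenyl)amino on a carbonyl carbon. Three measured steps swap a group at this same place, and all are small: a number 0.03 log units lower from compound 1 to compound 2 (within the scatter), a number 0.24 log units lower from compound 1 to compound 3 (within the scatter) and a number 0.21 log units lower from compound 2 to compound 3 (within the scatter). Each of those swaps involves groups larger than pyrrolidin-1-yl, so they guide the new step only loosely. The expected step in this assay is downward, estimated as a number 0.39 log units lower from compound 3 to compound 4 (beyond the scatter). For compound 4 the expected value is 2.72, with an estimated range from 2.35 to 3.05.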

Compound 4, partition coefficient: 2.72
Beside the measured number, compound 4's estimate shows no gap at the digits printed, within the range that was stated.
By their numbers in this assay, from the lowest: compound 4; then compounds 3, 2 and 1 (each within the scatter of the next).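

At this place on the carbonyl carbon, the earlier swaps all stayed within the scatter, but pyrrolidin-1-yl moves this assay beyond it, with a number 0.39 log units lower from compound 3 to compound 4 (beyond the scatter) and a number 0.60 log units lower from compound 2 to compound 4 (beyond the scatter) and a number 0.63 log units lower from compound 1 to compound 4 (beyond the scatter) in the three comparisons. So the choice of group here can shift this number measurably, and compound 4, carrying the smallest group of the four, stands lowest. No measurement shown explains the drop.

The compounds shown leave open whether the lower number goes with the ring or with the smaller group. Dimethylamino or piperidin-1-yl at this place would help separate the two.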